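The compounds below may be only part of what the source reports. "The series", "measured", "known", "first", "only" and "open" are said of these compounds alone.

In a functional assay on VCaP cells (Homo sapiens) for antiproliferative activity, read by propidium iodide staining, with a stated time of 96 h (on this read-out lower numbers stand for stronger inhibition and higher numbers for weaker inhibition), the values so far are these:

- Compound 1 `CC(O)(CSc1ccc(S(F)(F)(F)(F)F)cc1)C(=O)Nc1ccc([N+](=O)[O-])cc1C(F)(F)F` gives 26300 nM
- Compound 2 `CC(O)(CSc1ccc(S(F)(F)(F)(F)F)cc1)C(=O)Nc1ccc(S(F)(F)(F)(F)F)cc1` gives 28000 nM
- Compound 3 `CC(O)(CSc1ccc(F)cc1)C(=O)Nc1ccc(S(F)(F)(F)(F)F)cc1` gives 23000 nM

These three values lie within the scatter of one another, so compound 3 cannot be separated from compound 1 or compound 2 on these numbers.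

Compound 4 `CC(O)(CSc1ccc(C(F)(F)F)cc1)C(=O)Nc1ccc(S(F)(F)(F)(F)F)cc1` has trifluoromethyl in place of the fluoro of compound 3, on an aromatic carbon (trifluoromethyl in place of fluoro on an aromatic carbon). The closest evidence comes from that same carbon, where the measured change is a 1.2-fold lower number from compound 2 to compound 3 (0.09 log units; within the scatter) and so shows no real difference. Trifluoromethyl has more heavy atoms than fluoro and fewer than the group that fluoro replaced in that step, so the new group falls inside a swap that left the read-out unmoved. For the measured compounds named here, this is a single step, though, and no measured compound carries trifluoromethyl at this carbon.

The expected change is a 1.1-fold higher number from compound 3 to compound 4 (0.04 log units; within the scatter) and no shift beyond the scatter is expected in either direction. For compound 4 the estimated value is 25000 nM with an expected range from 14000 nM to 45000 nM in this assay terms.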

Compound 4, half-maximal inhibitory concentration: 24800 nM
Compound 4: middle estimate off by 1.0-fold (0.00 log units), on the high side, within the range that was stated.
By their numbers in this assay, from the lowest: compounds 3, 4, 1 and 2 (each within the scatter of the next).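

In this assay, the change 4-fluorophenyl to 4-(trifluoromethyl)phenyl gives a 1.1-fold higher number from compound 3 to compound 4 (0.03 log units; within the scatter), and placing trifluoromethyl on this aromatic carbon instead of the group of 6 heavy atoms gives a 1.1-fold lower number from compound 2 to compound 4 (0.05 log units; within the scatter). Until now, this carbon had been compared only with fluoro and that larger group, so a group of intermediate heavy-atom count is what this result adds: all three groups now stand within the scatter of one another, and this carbon shows no sensitivity to any of these three swaps. No measurement is available to explain why the read-out does not separate these groups.

Going by these compounds, all three groups at this carbon contain fluorine, so it remains open whether an amine, a carboxylic acid or a longer carbon chain there would give a number beyond the scatter. On these data alone, it also remains open whether a change elsewhere in the shared core, such as replacing its hydroxyl group with a hydrogen atom or a methoxy group, would move the read-out at all.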